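The compounds below may be only part of what the source reports. "The series", "measured", "known", "first", "only" and "open" are said of these compounds alone.

Two compounds of this series have been run in a functional assay on THP-1 cells (Homo sapiens) for antiproliferative activity, read by MTT assay, with a stated time of 48 h; a lower number here means a stronger inhibitor, a higher number a weaker inhibitor. Compound 1, `O=C(/C=C/[C@H](O)Cc1ccccc1)CCc1ccccc1`, gives 120000 nM there. Compound 2, `COc1ccc(CCC(=O)/C=C/[C@H](O)Cc2ccccc2)cc1OC`, gives 7530 nM in this assay, the lowest of the two numbers; its nearest neighbour is compound 1, whose number is higher by a margin beyond the scatter.

The step now considered goes from compound 2 to compound 3, `COc1ccc(CCC(=O)/C=C/[C@@H](O)Cc2ccccc2)cc1OC`. The two structures differ as follows: the two compounds have the same atoms and bonds and differ only in configuration as drawn: 1 of 2 stereo elements differ; a stereocentre at a saturated chain carbon is drawn R in compound 2 and S in compound 3. Within the data shown here, no measured pair in the set shows what inverting this stereocentre does, so the size and direction of the step rest on general expectation only: a change in configuration at the carbinol carbon is expected to shift the number upward, toward a weaker inhibitor, by a modest amount, with a wide spread in either direction. Compound 3 is accordingly estimated at 15000 nM in this assay, within 4000 nM to 60000 nM, which implies an expected step of a 2.0-fold higher number from compound 2 to compound 3 (0.30 log units; within the scatter).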

Compound 3, half-maximal inhibitory concentration: 32300 nM
Compound 3: middle estimate off by 2.2-fold (0.33 log units), on the low side, and the stated range covers the measured number.
By their numbers in this assay, from the lowest: compound 2; then compound 3; then compound 1.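

Inverting the stereocentre at the saturated chain carbon gives a 4.3-fold higher number from compound 2 to compound 3 (0.63 log units; beyond the scatter) in this assay, the first measured evidence in this series that the configuration at this position affects the read-out. For this pair, the R configuration as drawn carries the lower number, and the size of the step shows that this position is not indifferent to the change. The step can be assigned to this stereocentre alone because no other structural difference separates the two compounds: the fact that compounds 2 and 3 differ only in the configuration as drawn

On these data alone, it remains open whether the same inversion gives a step of similar size and direction on the core of compound 1, which lacks the two methoxy groups. Also open, as far as these compounds go, is how an amine or a methoxy group in place of the hydroxyl at this carbon would read in this assay.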